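Adding iodo to compound 2

A few compounds are considered here, and "the series" means these few. Any claim that something is new, unique, unknown or untested is made for them only; others in the source may bear on it.

In a functional assay on T98G cells (Homo sapiens) for cytotoxicity, read by MTT assay, with a stated time of 48 h (a higher number here means a weaker inhibitor, a lower number a stronger inhibitor), compound 2 `CC(=NNC(=S)Nc1ccccc1)c1ccccn1` gives 6.8 nM, and compound 3 `C/C(=N\NC(=S)Nc1ccccc1)c1ccccn1` stands level with it at 6.81 nM. Compound 1 `C/C(=N\NC(=S)Nc1ccc(I)cc1)c1ccccn1` lies clearly higher at 64 nM. Compound 4 `CC(=NNC(=S)Nc1ccc(I)cc1)c1ccccn1` arises from compound 2 by one change, iodo in place of hydrogen on an aromatic carbon, para to a large group. Going by the values given here, two measured steps bear on this. Where the double bond is drawn E in one structure and without a configuration in the other (the fact that one of compounds 2 and 3 is drawn with a defined configuration and the other without, at the place where they differ), the data show a 1.0-fold higher number from compound 2 to compound 3 (0.00 log units; within the scatter). Removing iodo gives a 9.4-fold lower number from compound 1 to compound 3 (0.97 log units; beyond the scatter), the same exchange in reverse. A rise of similar size is therefore expected here, an estimated 8.8-fold higher number from compound 2 to compound 4 (0.95 log units; beyond the scatter). For compound 4 the expected value is 60 nM, within an estimated range of 25 nM to 150 nM.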

Compound 4, half-maximal inhibitory concentration: 64 nM
Beside the measured number, compound 4's estimate is 1.1-fold (0.03 log units) below it; the range from low to high includes it.
By their numbers in this assay, from the lowest: compounds 2 and 3 (each within the scatter of the next); then compounds 1 and 4 (each within the scatter of the next).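

In this assay, iodo in place of hydrogen on the aromatic carbon gives a 9.4-fold higher number from compound 2 to compound 4 (0.97 log units; beyond the scatter), so the change now reads the same on two cores: the same change on two cores in this assay, a 9.4-fold lower number (0.97 log units; beyond the scatter) from compound 1 to compound 3 and a 9.4-fold lower number (0.97 log units; beyond the scatter) from compound 4 to compound 2, 1.0-fold (0.00 log units) apart, within the scatter of two such steps. Among the iodo compounds, the drawing of the double bond also leaves the number unmoved, with no change at the digits printed from compound 1 to compound 4 (within the scatter): the fact that one of compounds 1 and 4 is drawn with a defined configuration and the other without, at the place where they differ. The compounds shown carry only hydrogen and iodo at this place, so it remains open whether chloro, a methoxy group or an amine would fall nearer compound 2 or compound 4. From the compounds shown here alone, how iodo would act elsewhere on this ring also stays open.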